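A few compounds are considered here, and "the series" means these few. Any claim that something is new, unique, unknown or untested is made for them only; others in the source may bear on it.

Measured so far:
Compound 1 `COc1ccc(S(=O)(=O)Nc2cc(Cl)cc(Cl)c2)cc1N1CCNCC1`: 0.631 nM
Compound 2 `COc1ccc(S(=O)(=O)Nc2cc(Br)cc(Br)c2)cc1N1CCNCC1`: 0.501 nM
Compound 3 `COc1ccc(S(=O)(=O)Nc2ccc(Cl)c(Cl)c2)cc1N1CCNCC1`: 2.51 nM

All three share one core and differ only in the halogenated ring on the sulfonamide nitrogen. In an assay on isolated protein for binding affinity to 5-hydroxytryptamine receptor 6 (Homo sapiens) (on this read-out higher numbers stand for weaker inhibition and lower numbers for stronger inhibition), compound 2 gives the lowest of the three numbers, though the step of a 1.3-fold lower number from compound 1 to compound 2 (0.10 log units; within the scatter) is too small to count, while compound 3 sits clearly apart a 5.0-fold higher number from compound 2 to compound 3 (0.70 log units; beyond the scatter).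

Compound 4 `COc1ccc(S(=O)(=O)Nc2cc(Br)cc(Cl)c2Br)cc1N1CCNCC1` has not yet been measured. Compared with compound 2, the change is 2,5-dibromo-3-chlorophenyl in place of 3,5-dibromophenyl on a sulfonamide nitrogen. Among the compounds with values here, no measured step covers this exact change. The closest guide is the move from compound 1 to compound 3 a 4.0-fold higher number from compound 1 to compound 3 (0.60 log units; beyond the scatter) and from compound 2 to compound 3 a 5.0-fold higher number from compound 2 to compound 3 (0.70 log units; beyond the scatter), where a different arrangement of two halogens on that ring gave a modestly higher number. Swapping one bromine for a chlorine, as in compound 1 to compound 2, barely mattered. Compound 4 keeps a halogen at each of the two places compound 2 has them and adds a third, so a small rise in the number is expected, with wide uncertainty: the step of a 3.0-fold higher number from compound 2 to compound 4 (0.48 log units; beyond the scatter) is the estimate. For compound 4 the expected value is 1.5 nM, within roughly 0.3 nM to 8 nM.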

Compound 4, inhibition constant: 3.98 nM
The estimate for compound 4 lay 2.7-fold (0.42 log units) below the measured number, within the range that was stated.
By their numbers in this assay, from the lowest: compounds 2 and 1 (each within the scatter of the next); then compounds 3 and 4 (each within the scatter of the next).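

Within the data shown here, on the ring attached to the sulfonamide nitrogen, the earlier compounds showed only the effect of moving or swapping two halogens; compound 4 shows what happens when the ring gains another one. In this assay, replacing 3,5-dibromophenyl, with its two bromines, by 2,5-dibromo-3-chlorophenyl, with two bromines and one chlorine, gives a clear rise (with a 7.9-fold higher number from compound 2 to compound 4 (0.90 log units; beyond the scatter)), and the comparison with the dichloro ring agrees (with a 6.3-fold higher number from compound 1 to compound 4 (0.80 log units; beyond the scatter)). The step to compound 4 from the 3,4-dichlorophenyl ring stays within the scatter (with a 1.6-fold higher number from compound 3 to compound 4 (0.20 log units; within the scatter)), so these two differently halogenated rings cannot be separated, and among these four compounds only the two 3,5-dihalogenated rings reach the lowest group of numbers.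

No measurement here explains why the number rises when the ring changes in this way. Also open, on these data alone, is how the number would respond if a nitrile, an amine or a carboxylic acid stood on this ring in place of the halogens, or if the ring carried a single bromine.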